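This account rests on a few compounds, and the source may have more. Where it says the series, first, only, none or still open, it means among the compounds named here.

In an ADME assay on the whole organism (strain FVB) for pharmacokinetics, with Mus musculus as the target, read by LC-MS, at a dose of 30 mg/kg by the oral route (a higher number here means more compound in the circulation at the dose given, a lower number less compound in the circulation), three compounds sharing one core have been measured: compound 1 `CC(C)(O)CNCCCOc1ccc([C@H]2CC[C@]3(CC2)OOC2(O3)C3CC4CC(C3)CC2C4)cc1` gives 1210 nM, compound 2 `CC(C)(CN)Oc1ccc([C@H]2CC[C@]3(CC2)OOC2(O3)C3CC4CC(C3)CC2C4)cc1` gives 529 nM and compound 3 `NCCCCOc1ccc([C@H]2CC[C@]3(CC2)OOC2(O3)C3CC4CC(C3)CC2C4)cc1` gives 370 nM. This last value cannot be separated from one neighbour, at a 1.4-fold lower number from compound 2 to compound 3 (0.16 log units; within the scatter), but lies clearly under the other, at a 3.3-fold lower number from compound 1 to compound 3 (0.51 log units; beyond the scatter).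

Compound 4 `O[C@H]1CC[C@H](NCCCOc2ccc([C@H]3CC[C@]4(CC3)OOC3(O4)C4CC5CC(C4)CC3C5)cc2)CC1` alters compound 3 in one place: (4-hydroxycyclohexyl)amino in place of aminomethyl on a saturated chain carbon, three bonds along the chain from an oxygen on an aromatic ring. The change sits on a saturated chain carbon, three bonds along the chain from an oxygen on an aromatic ring. The closest guide is compound 1, at 1210 nM, which carries (2-hydroxy-2-methylpropyl)amino at that same place. Its step to compound 3 makes the same kind of swap, so, read in reverse, it points towards a higher number. Within the data shown here, no measured compound carries the six-membered ring, so this comparison is only approximate.

The estimated step is a 2.3-fold higher number from compound 3 to compound 4 (0.36 log units; beyond the scatter), a modest expected rise. For compound 4 the estimate is 850 nM, with an expected range of 330 nM to 2200 nM.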

Compound 4, maximal plasma concentration: 721 nM
Estimate against measurement, compound 4: 1.2-fold (0.07 log units) above; the range from low to high includes it.
By their numbers in this assay, from the lowest: compounds 3, 2, 4 and 1 (each within the scatter of the next, the first and the last beyond it).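

In this assay, 4-hydroxycyclohexyl in place of 2-hydroxy-2-methylpropyl on an amine nitrogen cannot be told apart from the original (a 1.7-fold lower number from compound 1 to compound 4 (0.22 log units; within the scatter)), so a six-membered carbon ring can sit on this nitrogen with no separable shift in the read-out. Compound 4 also cannot be separated from the two compounds without a substituted chain amine (a 1.9-fold higher number from compound 3 to compound 4 (0.29 log units; within the scatter); a 1.4-fold higher number from compound 2 to compound 4 (0.13 log units; within the scatter)), although compound 1 and compound 3 do stand apart beyond the scatter, so compound 4 falls in the overlap rather than clearly with either end. Nothing measured here explains these numbers.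

Plain cyclohexyl on the same nitrogen would test whether the ring's hydroxyl matters to the read-out. Going by these compounds, the other stereoisomer of 4-hydroxycyclohexyl, or a morpholine ring at this place, also remains open.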